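A few compounds are considered here, and "the series" means these few. Any claim that something is new, unique, unknown or untested is made for them only; others in the source may bear on it.

In a functional assay on U2OS cells for antagonist activity at C-X-C chemokine receptor type 3 (Homo sapiens), read by beta-arrestin recruitment (on this read-out higher numbers stand for weaker inhibition and lower numbers for stronger inhibition), three compounds of one series have been measured. Compound 1 `Cc1nc(-c2nc3ccccc3[nH]2)c(N2CCN(C(=O)Cn3cnc4cccnc43)[C@H](C)C2)s1` gives 1050 nM, compound 2 `COc1ncc(-c2nc(C(F)(F)F)sc2N2CCN(C(=O)Cn3cnc4cccnc43)[C@H](C)C2)cn1` gives 177 nM, and compound 3 `COc1ncc(-c2nc(C(F)(F)F)sc2N2CCN(C(=O)Cn3nc(C)nc3C)[C@H](C)C2)cn1` gives 558 nM. Compound 3 thus stands second highest of the three; its nearest neighbour is compound 1, within the scatter, and its furthest is compound 2, beyond it. The one step that connects two of these compounds, a 3.2-fold higher number from compound 2 to compound 3 (0.50 log units; beyond the scatter), swaps the group on the saturated chain carbon bound to the carbonyl carbon. Compound 4 `CCCc1ncc(-c2nc(C(F)(F)F)sc2N2CCN(C(=O)Cn3nc(C)nc3C)[C@H](C)C2)cn1` differs from compound 3 in another place: propyl in place of methoxy on an aromatic carbon. For the measured compounds named here, none of the measured steps touches this position; the single measured change sits elsewhere in the molecule, so nothing in the numbers points in a direction for this swap. The expectation for compound 4 in this assay is therefore a step of a 1.1-fold lower number from compound 3 to compound 4 (0.03 log units; within the scatter), that is, none beyond the scatter. Compound 4 is estimated to give about 520 nM, with a range from 180 nM to 1500 nM.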

Compound 4, half-maximal inhibitory concentration: 258 nM
Beside the measured number, compound 4's estimate is 2.0-fold (0.30 log units) above it, within the range that was stated.
By their numbers in this assay, from the lowest: compounds 2 and 4 (each within the scatter of the next); then compounds 3 and 1 (each within the scatter of the next).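

For the compounds shown here, the swap of 2-methoxypyrimidin-5-yl to 2-propylpyrimidin-5-yl gives a 2.2-fold lower number from compound 3 to compound 4 (0.34 log units; beyond the scatter) in this assay and so shows that this position, which no earlier step had touched, does bear on the read-out. The oxygen of the methoxy group and its hydrogen-bond acceptor are not required for inhibition in this pair, since the all-carbon propyl chain moves the number down rather than up. No measurement at hand explains why this step goes in this direction.

Going by these compounds, whether the same gain holds with the group that compound 2 carries on the saturated chain carbon remains open. Also open, on these data alone, is how a shorter ethyl chain, a longer butyl chain or an amine on this aromatic carbon would compare with the propyl group of compound 4.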